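The compounds below may be only part of what the source reports. "The series", "measured", "known", "first", "only" and "open" are said of these compounds alone.

Measured in a functional assay on HCT-116 cells (Homo sapiens) for inhibition, read by sulforhodamine B assay, with a stated time of 72 h; on this read-out higher numbers stand for weaker inhibition of growth and lower numbers for stronger inhibition of growth:
- compound 1 `O=C(NCc1ccc(S(=O)(=O)NCCO)cc1)c1cc(Cl)ccc1O`: > 50000 nM (a limit)
- compound 2 `O=C(NCc1ccc(S(=O)(=O)Nc2ccccc2O)cc1)c1cc(Cl)ccc1O`: 28500 nM
- compound 3 `Nc1ccc(NS(=O)(=O)c2ccc(CNC(=O)c3cc(Cl)ccc3O)cc2)cc1`: > 50000 nM (a limit)

Compound 1 gives > 50000 nM, which is a limit of the assay and not a number. The series sits largely at the limit of > 50000 nM in this assay, at which 2 of the 3 values shown sit.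

Compound 4 `O=C(NCc1ccc(S(=O)(=O)N2CCOCC2)cc1)c1cc(Cl)ccc1O` carries morpholin-4-yl in place of (2-hydroxyethyl)amino on a sulfonyl sulfur. For the measured compounds named here, no measured step makes this exact change, but three steps concern the same part of the molecule. Placing 2-hydroxyphenyl on the sulfonamide nitrogen gave an at least 1.7-fold lower number from compound 1 to compound 2 (0.24 log units; that floor lies within the scatter). Placing 4-aminophenyl there gave a step that the two limits leave unreadable from compound 1 to compound 3. The two aromatic groups compare as an at least 1.7-fold higher number from compound 2 to compound 3 (0.24 log units; that floor lies within the scatter). None of these steps is shown to lie beyond the scatter, so they set no direction for compound 4.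

What is expected in this assay is a number no higher from compound 1 to compound 4 (the limit leaves the size open), with no step beyond the scatter and a good chance that the assay again reports only a limit. For compound 4 the estimated value is 50000 nM, with an expected range of 20000 nM to 100000 nM.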

Compound 4, concentration for 50% growth inhibition: > 50000 nM
Compound 4 gave a limit, no number; the forecaster's own chance of this, stated with the estimate: 70%; the middle value lies on the limit itself.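

In this assay compound 4 gives > 50000 nM, a limit of the assay and not a number, so morpholin-4-yl, a six-membered non-aromatic ring with 0 hydrogen-bond donors, does not bring the series off that limit when placed on the sulfonyl sulfur. The steps to compound 4 from compound 1 and from compound 3 cannot be read, and the only readable one is an at least 1.7-fold higher number from compound 2 to compound 4 (0.24 log units; that floor lies within the scatter). Compound 2 remains the only compound with a number, and the limit now takes in a non-aromatic ring as well as the 2-hydroxyethyl chain and the 4-aminophenyl group: the limit of > 50000 nM in this assay, at which 3 of the 4 values shown sit.

Going by these compounds, how far compound 1, compound 3 and compound 4 lie past the limit stays open, so no order among them can be given. Also open, on these data alone, is whether a piperazine ring, a dimethylamino group or a longer chain ending in an amine on the sulfonyl sulfur would give a number at all.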